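The compounds below may be only part of what the source reports. "The series", "measured", "known", "first", "only" and "open" are said of these compounds alone.

Compound 1 `CC(C)C(=O)Nc1cccc(S(=O)(=O)Oc2ccccc2C(C)C)c1` and compound 2 `CC(C)c1ccccc1OS(=O)(=O)c1cccc(NC(=O)C(C)(C)C)c1` share a core and differ at one place: methyl in place of hydrogen on a saturated chain carbon bound to a carbonyl carbon and two saturated chain carbons. In a functional assay on MCF7 cells (Homo sapiens) for antiproliferative activity, read by sulforhodamine B assay, with a stated time of 48 h (a lower number here means a stronger inhibitor, a higher number a weaker inhibitor), compound 1 gives 13000 nM, and compound 2 gives 14000 nM, so the step is a 1.1-fold higher number from compound 1 to compound 2 (0.03 log units; within the scatter). Compound 3 `CCC(=O)Nc1ccc(S(=O)(=O)Oc2ccccc2C(C)C)cc1` is built on a different core; how its core differs from that of compound 1 is not broken down here. In this assay compound 3 gives 11000 nM, a number that sits within the scatter of the other two. Compound 4 `CCCC(=O)Nc1ccc(S(=O)(=O)Oc2ccccc2C(C)C)cc1` has not yet been measured; it differs from compound 3 by methyl in place of hydrogen on a saturated chain carbon, two bonds along the chain from a carbonyl carbon. This is the same kind of change as that from compound 1 to compound 2, but the place is not the same: there the methyl enters on a saturated chain carbon bound to a carbonyl carbon and two saturated chain carbons, here on a saturated chain carbon two bonds along the chain from a carbonyl carbon. Because the earlier step of a 1.1-fold higher number from compound 1 to compound 2 (0.03 log units; within the scatter) stayed within the scatter, a step of about no change at the digits printed from compound 3 to compound 4 (within the scatter) is expected here, and compound 4 is estimated at 11000 nM in this assay, with a likely range from 6000 nM to 22000 nM.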

Compound 4, half-maximal inhibitory concentration: 6600 nM
Compound 4: middle estimate off by 1.7-fold (0.22 log units), on the high side; low and high end bracket the measured number.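

In this assay the new step is a 1.7-fold lower number from compound 3 to compound 4 (0.22 log units; within the scatter) and, set beside the earlier step, it shows no difference between the two cores: the same change on two cores in this assay, a 1.1-fold higher number (0.03 log units; within the scatter) from compound 1 to compound 2 and a 1.7-fold lower number (0.22 log units; within the scatter) from compound 3 to compound 4, 1.8-fold (0.25 log units) apart, within the scatter of two such steps. Within these four compounds, then, a methyl in place of a hydrogen on the saturated chain gives a step within the scatter on both the core of compound 1 and the core of compound 3. Going by these compounds alone, this does not show that the change carries over in any stricter sense: the methyl enters at a different place on each core, each core offers only one pair, and a small real effect cannot be told apart from none.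

The compounds shown leave open whether a chain longer than propylcarbonyl, or an amine or a carboxylic acid at the end of the chain, would give a step beyond the scatter on either core. They also leave open how the two cores compare when they carry one and the same chain.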